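This account rests on a few compounds, and the source may have more. Where it says the series, first, only, none or still open, it means among the compounds named here.

In an ADME assay on NIH3T3 cells (Mus musculus, strain Balb/c) for inhibition, read by neutral red uptake, with a stated time of 48 h (a lower number here means a stronger inhibitor, a higher number a weaker inhibitor), compound 1 `CC(C)=CCC/C(C)=C/CN(c1ccc(O)cc1)S(C)(=O)=O` gives 158000 nM and compound 2 `CC(C)=CCC/C(C)=C/CNc1ccc(O)cc1` gives 308000 nM. Hydrogen in place of methylsulfonyl on a nitrogen on an aromatic ring is the only measured change, and it shows a 1.9-fold higher number from compound 1 to compound 2 (0.29 log units; within the scatter). Compound 2 therefore stands within the scatter of compound 1. Compound 3 `CC(C)=CCC/C(C)=C/CNc1ccccc1` is derived from compound 2 by hydrogen in place of hydroxy on an aromatic carbon. Going by the values given here, no measured step touches this hydroxy, so the data give no direction for the change. The nearest guide for compound 3 is the change at the nitrogen, a 1.9-fold higher number from compound 1 to compound 2 (0.29 log units; within the scatter), and no shift beyond the scatter is therefore expected in this assay. The expected outcome is a 1.2-fold lower number from compound 2 to compound 3 (0.09 log units; within the scatter). For compound 3 the estimated value is 250000 nM, with an expected range of 100000 nM to 600000 nM.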

Compound 3, half-maximal inhibitory concentration: 1680000 nM
Beside the measured number, compound 3's estimate is 6.7-fold (0.83 log units) below it, and the stated range ends below it.
By their numbers in this assay, from the lowest: compounds 1 and 2 (each within the scatter of the next); then compound 3.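

In this assay, the hydroxy para to a large group on the six-membered aromatic ring is the first place shown where a single change moves the number beyond the scatter: hydrogen in place of hydroxy gives a 5.5-fold higher number from compound 2 to compound 3 (0.74 log units; beyond the scatter). The change at the nitrogen, by contrast, gives a 1.9-fold higher number from compound 1 to compound 2 (0.29 log units; within the scatter), so among the steps shown, this position is the one that separates the compounds, and the compound that keeps the hydroxy is the stronger inhibitor of this pair. No measured evidence is available to explain this shift.

As far as these compounds go, what a methoxy, an amine or a fluorine at this same place on the ring would give stays open. Also open, from the compounds shown here alone, is whether methylsulfonyl on the nitrogen would have any effect on a ring without the hydroxy.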